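A few compounds are considered here, and "the series" means these few. Any claim that something is new, unique, unknown or untested is made for them only; others in the source may bear on it.

Compound 1 `N#Cc1cccc(C(=O)N[C@@H]2CCC[C@H](NC(=O)c3ccccn3)C2)c1`: in a functional assay on HEK293 cells for antagonist activity at metabotropic glutamate receptor 5 (Homo sapiens), read by FLIPR and calcium flux (a higher number here means a weaker inhibitor, a lower number a stronger inhibitor), compound 1 reaches only the assay limit of > 10000 nM. Compound 2 `N#Cc1cccc(C(=O)N[C@@H]2CCC[C@@H](NC(=O)c3ccccn3)C2)c1`: in this assay compound 2 gives 231 nM.

For the measured compounds named here, compound 2 thus holds the only true number measured so far; the other result is a limit. Compound 3 `N#Cc1cccc(C(=O)N[C@H]2CCC[C@H](NC(=O)c3ccccn3)C2)c1` differs from compound 2 in that (the two compounds have the same atoms and bonds and differ only in configuration as drawn: 2 of 2 stereo elements differ (all stereocentres are inverted: mirror images); a stereocentre at a saturated ring carbon is drawn R in compound 2 and S in compound 3; a stereocentre at a saturated ring carbon is drawn R in compound 2 and S in compound 3). Going by the values given here, the single measured step, an at least 43-fold lower number from compound 1 to compound 2 (1.63 log units; beyond the scatter), shows that configuration at one ring carbon can change the number greatly, a comparison that rests on (the fact that compounds 1 and 2 differ only in the configuration as drawn). That step concerns a different kind of change, so it guides only loosely. A mirror image is nevertheless expected to weaken inhibition, an expected step of an 11-fold higher number from compound 2 to compound 3 (1.03 log units; beyond the scatter). Compound 3 is therefore estimated at 2500 nM, within 400 nM to 10000 nM.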

Compound 3, half-maximal inhibitory concentration: > 10000 nM
Compound 3 was reported as a limit (the forecaster's own chance of this, stated with the estimate: 35%); middle value at least 4.0-fold (0.60 log units) away from the limit.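

Inverting both ring stereocentres brings an at least 43-fold higher number from compound 2 to compound 3 (1.63 log units; beyond the scatter) in this assay, and nothing else in the structure changes: the fact that compounds 2 and 3 differ only in the configuration as drawn. Among the three compounds, only compound 2 gives a true number, while compound 1 and compound 3 both stand at the assay limit, so activity here depends on one specific arrangement at the ring carbons. The step from compound 1 to compound 3 cannot be read, as both values are limits.

On these data alone, the mirror image of compound 1 remains open. So does whether compound 2's arrangement would stay active with a carboxylic acid in place of the nitrile.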